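Notes on the aryl group of compound 2 and compound 3

A few compounds are considered here, and "the series" means these few. Any claim that something is new, unique, unknown or untested is made for them only; others in the source may bear on it.

Measured so far:
compound 1 `COc1ccc(-c2cn3ccnc3c(-c3ccc4ncn(C5CCCCC5)c4c3)n2)cc1`: 92% in a functional assay on K562 cells (Homo sapiens) for inhibition, read by sulforhodamine B assay, with a stated time of 48 h, tested at 10 uM; on this read-out lower numbers stand for less inhibition and higher numbers for more inhibition at the one concentration tested (going by the name of the read-out)
compound 2 `Brc1ccc(-c2cn3ccnc3c(-c3ccc4ncn(C5CCCCC5)c4c3)n2)cc1`: 59% in this assay

Compound 2 stands lowest of the two numbers; its nearest neighbour is compound 1, and the step of a number 33 percentage points lower from compound 1 to compound 2 (beyond the scatter) lies beyond the scatter. Compound 3 `COc1ccccc1-c1cn2ccnc2c(-c2ccc3ncn(C4CCCCC4)c3c2)n1` is not yet measured. The change is 2-methoxyphenyl in place of 4-bromophenyl on an aromatic carbon. Within the data shown here, the one step that bears on it, a number 33 percentage points lower from compound 1 to compound 2 (beyond the scatter), ran the other way, bromo replacing methoxy, and was large; here a methoxyphenyl returns, though as 2-methoxyphenyl rather than the 4-methoxyphenyl of compound 1, so a rise beyond the scatter is expected but with less certainty than a direct reversal would give. For compound 3 the expected step is a number 19 percentage points higher from compound 2 to compound 3 (beyond the scatter). Compound 3 is therefore estimated at 78%, within 55% to 95%.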

Compound 3, a percentage reported as inhibition, at one concentration (the size of the read-out at that concentration, not a potency): 22.6%
Estimate against measurement, compound 3: 55.4 percentage points above; measured number below the stated range.
By their numbers in this assay, from the lowest: compound 3; then compound 2; then compound 1.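

The methoxy group alone does not secure a high number at this position: in this assay, moving it from 4-methoxyphenyl to 2-methoxyphenyl gives a number 69.4 percentage points lower from compound 1 to compound 3 (beyond the scatter), so its place on the phenyl ring matters. Against 4-bromophenyl, 2-methoxyphenyl gives a number 36.4 percentage points lower from compound 2 to compound 3 (beyond the scatter), so methoxy does not outrank bromo regardless of its place on the ring. Nothing available accounts for this loss.

Going by these compounds, whether a bromo group placed as the methoxy of compound 3 would also lower the number stays open. So does how an amine or a carboxylic acid would read in place of the methoxy of compound 1.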